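Moving the fluorine on the aryl at the aromatic nitrogen

The compounds below may be only part of what the source reports. "The series", "measured", "known", "first", "only" and "open" are said of these compounds alone.

In a functional assay on the whole organism (strain Swiss albino) for inhibition, with Mus musculus as the target, in the writhing test, with a stated time of 30 min, at a dose of 20 mg/kg by the oral route (a higher number here means a stronger effect of the compound at the dose given, a lower number a weaker effect), compound 1 `Cc1c(C=O)cc(-c2ccc(S(C)(=O)=O)cc2)n1-c1cccc(F)c1` gives 44%. Compound 2 `Cc1c(/C=N\O)cc(-c2ccc(S(C)(=O)=O)cc2)n1-c1ccc(F)cc1` gives 41% in this assay, the lower of the two numbers shown, though the gap to compound 1 lies within the scatter. Compound 3 `Cc1c(/C=N\O)cc(-c2ccc(S(C)(=O)=O)cc2)n1-c1cccc(F)c1` differs from compound 2 in one place: 3-fluorophenyl in place of 4-fluorophenyl on an aromatic nitrogen. Among the measured compounds shown here, no step between measured compounds isolates this change, so its size cannot be read off; with compound 1 and compound 2 sitting within the scatter of each other, no step beyond the scatter is expected in this assay. Compound 3 is estimated at 43%, between 30% and 56%, a step of a number 2 percentage points higher from compound 2 to compound 3 (within the scatter) expected to stay within the scatter.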

Compound 3, a percentage reported as inhibition, in the whole organism at one dose (the size of the read-out at that dose, not a potency): 42%
For compound 3 the middle estimate is 1 percentage points above the measured one, and the stated range covers the measured number.
By their numbers in this assay, from the lowest: compounds 2, 3 and 1 (each within the scatter of the next).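

In this assay, 3-fluorophenyl in place of 4-fluorophenyl on the aromatic nitrogen gives a number 1 percentage points higher from compound 2 to compound 3 (within the scatter), so this move now has a measured size, and it does not separate the two compounds. With 3-fluorophenyl held fixed, the group of 3 heavy atoms in place of the group of 2 heavy atoms on the aromatic carbon gives a number 2 percentage points lower from compound 1 to compound 3 (within the scatter), so this change does not separate its pair either. Nothing available bears on the reason for these results.

From the compounds shown here alone, whether a chlorine or methoxy group in place of the fluorine, or a nitrile or carboxylic acid on the aromatic carbon, would move the read-out beyond the scatter stays open. Going by these compounds, these readings show only the size of the effect at the one dose given; whether the effect would be stronger or weaker at any other dose stays open.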